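From Compound 3 to Compound 4: Benzyl Replaces Tert-Butoxycarbonyl

The compounds below may be only part of what the source reports. "The series", "measured", "known", "first", "only" and "open" are said of these compounds alone.

Compound 1 `COc1cc2nc(N3CCC4CCC(C3)N4C(=O)OC(C)(C)C)nc(Nc3ccc(S(C)(=O)=O)cc3F)c2cc1OC` gives 56.9% in a functional assay on HEK293 cells for agonist activity at Glucose-dependent insulinotropic receptor (Homo sapiens), read by cAMP accumulation, with a stated time of 60 min; on this read-out higher numbers stand for larger maximal responses and lower numbers for smaller maximal responses. Compound 2 `COc1cc2nc(N3CCC4CCC(C3)N4Cc3ccccc3)nc(Nc3ccc(S(C)(=O)=O)cc3F)c2cc1OC` gives 44.3% in this assay, and compound 3 `COc1cc2nc(N3CCC4CCC(C3)N4C(=O)OC(C)(C)C)nc(Nc3ccc(S(C)(=O)=O)cc3)c2cc1OC` gives 32.7% there. Compound 3 therefore stands lowest of the three measured numbers: compound 2 lies nearest to it and compound 1 furthest, and both gaps lie beyond the scatter. The step of a number 12.6 percentage points lower from compound 1 to compound 2 (beyond the scatter) goes with the exchange of benzyl for tert-butoxycarbonyl, while the step of a number 24.2 percentage points lower from compound 1 to compound 3 (beyond the scatter) goes with hydrogen in place of fluoro.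

Compound 4 `COc1cc2nc(N3CCC4CCC(C3)N4Cc3ccccc3)nc(Nc3ccc(S(C)(=O)=O)cc3)c2cc1OC` differs from compound 3 by benzyl in place of tert-butoxycarbonyl on an amine nitrogen in a ring. Among the compounds with values here, the one measured step that bears on this change is a number 12.6 percentage points lower from compound 1 to compound 2 (beyond the scatter), a modest fall beyond the scatter. The same exchange on compound 3 is expected to bring a modest fall of similar size, namely a number 11.7 percentage points lower from compound 3 to compound 4 (beyond the scatter) in this assay. On that basis compound 4 is estimated to reach 21% in this assay, with a range from 8% to 35% that reflects a single precedent.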

Compound 4, largest response reached (Emax), in percent of the reference or control that the assay uses: 23.4%
The estimate for compound 4 lay 2.4 percentage points below the measured number; the range from low to high includes it.
By their numbers in this assay, from the lowest: compounds 4 and 3 (each within the scatter of the next); then compound 2; then compound 1.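

In this assay, the exchange of benzyl for tert-butoxycarbonyl on the core that lacks fluoro gives a number 9.3 percentage points lower from compound 3 to compound 4 (within the scatter), so on this core the exchange does not separate the two compounds, yet the step matches the one seen on the fluoro core: the same change on two cores in this assay, a number 12.6 percentage points lower (beyond the scatter) from compound 1 to compound 2 and a number 9.3 percentage points lower (within the scatter) from compound 3 to compound 4, 3.3 percentage points apart, within the scatter of two such steps. The change from fluoro to hydrogen on an aromatic carbon now has a second reading, a number 20.9 percentage points lower from compound 2 to compound 4 (beyond the scatter), with benzyl in place of tert-butoxycarbonyl on the amine nitrogen, and it agrees with the first: the same change on two cores in this assay, a number 24.2 percentage points lower (beyond the scatter) from compound 1 to compound 3 and a number 20.9 percentage points lower (beyond the scatter) from compound 2 to compound 4, 3.3 percentage points apart, within the scatter of two such steps. Across these four compounds, then, fluoro goes with the higher number whichever of the two groups sits on that nitrogen.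

The compounds shown leave open whether chloro or methoxy on that aromatic carbon would behave as fluoro does. They also leave open whether acetyl or a free amine hydrogen on the ring nitrogen would fit the same steps.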